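Isopropoxy to 2,2,2-trifluoroethoxy on compound 2

The source may hold more compounds than are shown below. What is called first, only, known or untested is meant among the compounds shown, and "the series" means these compounds.

Measured in an in vivo ADME assay on the whole organism (strain Sprague-Dawley) for pharmacokinetics, with Rattus norvegicus as the target; on this read-out higher numbers stand for wider distribution into tissues and lower numbers for narrower distribution:
Compound 1 `Cc1cc(CCC(=O)O)ccc1-c1noc(-c2ccc(OC(C)C)c(C(F)(F)F)c2)n1`: 1.1 L/kg
Compound 2 `Cc1cc(CCC(=O)O)ccc1-c1noc(-c2ccc(OC(C)C)c(C#N)c2)n1`: 0.2 L/kg

Of these two, compound 2 holds the lower number. Compound 3 `Cc1cc(CCC(=O)O)ccc1-c1noc(-c2ccc(OCC(F)(F)F)c(C#N)c2)n1` is not yet measured and differs from compound 2 in one place: 2,2,2-trifluoroethyl in place of isopropyl on an oxygen on an aromatic ring. That is, 2,2,2-trifluoroethyl stands in place of isopropyl on an oxygen on an aromatic ring.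

Among the measured compounds shown here, the only measured step, a 5.5-fold lower number from compound 1 to compound 2 (0.74 log units; beyond the scatter), lies beyond the scatter, but it is a cyano in place of trifluoromethyl on an aromatic carbon. For the measured compounds named here, it bears on this exchange only indirectly, showing that one change can move the number, and no measured step tests the exchange itself. The expectation therefore starts from compound 2 at 0.2 L/kg, and no shift beyond the scatter is expected. The expected step is a 1.3-fold higher number from compound 2 to compound 3 (0.10 log units; within the scatter). For compound 3 the estimated value is 0.25 L/kg, with an expected range of 0.12 L/kg to 0.5 L/kg.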

Compound 3, volume of distribution at steady state: 0.1 L/kg
Compound 3: the middle estimate sits 2.5-fold (0.40 log units) above what was measured; the whole stated range lies above it.
By their numbers in this assay, from the lowest: compounds 3 and 2 (each within the scatter of the next); then compound 1.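

In this assay, placing 2,2,2-trifluoroethyl on the oxygen in place of isopropyl gives a 2.0-fold lower number from compound 2 to compound 3 (0.30 log units; within the scatter) and so stays within the scatter, which means this exchange on the oxygen does not clearly move the distribution read-out while the cyano group is present. The earlier compounds had shown a clear effect only at the other substituent, through a 5.5-fold lower number from compound 1 to compound 2 (0.74 log units; beyond the scatter), and had not tested the oxygen substituent at all. Nothing available here accounts for the result.

The compounds shown leave open whether the same exchange would stay within the scatter with trifluoromethyl in place of cyano. They also leave open how this assay would respond to other groups on this oxygen, such as a longer alkyl chain, a cyclopropylmethyl group or a chain ending in an amine.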